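The compounds below may be only part of what the source reports. "The series", "measured", "known", "first", "only" and "open" are said of these compounds alone.

Measured so far:
- compound 1, `Oc1cccc(CNc2cc(Br)cc3[nH]ncc23)c1`: 55%
- compound 2, `Nc1cccc(CNc2cc(Br)cc3[nH]ncc23)c1`: "not active" (no number reported)
- compound 3, `FC(F)(F)c1cccc(CNc2cc(Br)cc3[nH]ncc23)c1`: 56%

All three share one core and differ only in the group on the outer aromatic ring. In an assay for inhibition of Tryptophan 2,3-dioxygenase (Homo sapiens), with a stated time of 1 h, tested at 10 uM (on this read-out higher numbers stand for more inhibition at the one concentration tested (going by the name of the read-out) and lower numbers for less inhibition), compound 3 gives 56%, and compound 1 gives 55%; these two lie within the scatter of each other, so neither can be called stronger. Compound 2 gave no number in this assay, only a report of no activity.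

Compound 4, `O=C(O)Nc1cccc(CNc2cc(Br)cc3[nH]ncc23)c1`, differs from compound 3 in one place: carboxyamino in place of trifluoromethyl on an aromatic carbon.

Going by the values given here, only one measured step touches this position: a number 1 percentage points higher from compound 1 to compound 3 (within the scatter), a step within the scatter. So swapping hydroxy for trifluoromethyl changed nothing measurable, while the amino group of compound 2 left no measurable inhibition at all. Among the compounds with values here, the carboxyamino group brings hydrogen-bond donors, as hydroxy and amino did, but no step tells how such a group fares here, so the direction is open.

Compound 4 is therefore expected to give about 40%, with a range from 5% to 65%. That estimate means a step of a number 16 percentage points lower from compound 3 to compound 4 (beyond the scatter), with a real chance of no number at all.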

Compound 4, a percentage reported as inhibition, at one concentration (the size of the read-out at that concentration, not a potency): "not active" (no number reported)
Nothing numeric was reported for compound 4; the estimate stays without a comparison.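

Going by these compounds alone, compound 4 carries only a report of no activity, so no numeric step from compound 3 to compound 4 can be read. The compounds shown leave open why compound 2 and compound 4 gave no number while compound 1 and compound 3 did. No measured evidence here bears on this result.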